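The compounds below may be only part of what the source reports. "The series", "measured", "known", "first", "only" and "open" are said of these compounds alone.

Working notes on the series. Compound 1 is `C=CCNC(=S)NC1=C(C#N)C(c2ccc(Cl)cc2Cl)C2=C(CCCC2=O)N1c1ccc(S(N)(=O)=O)cc1`, compound 2 is `N#CC1=C(NC(=S)Nc2ccccc2)N(c2ccc(S(N)(=O)=O)cc2)C2=C(C(=O)CCC2)C1c1ccc(Cl)cc1Cl` and compound 3 is `N#CC1=C(NC(=S)Nc2ccc(Br)cc2)N(c2ccc(S(N)(=O)=O)cc2)C2=C(C(=O)CCC2)C1c1ccc(Cl)cc1Cl`; compound 4, `N#CC1=C(N2C(=O)CCC2=O)N(c2ccc(S(N)(=O)=O)cc2)C2=C(C(=O)CCC2)C1c1ccc(Cl)cc1Cl`, has not yet been measured. In a functional assay on Ehrlich cells (Mus musculus) for cytotoxicity, read by trypan blue exclusion, with a stated time of 2 h, tested at 50 ug/mL (a higher number here means a stronger effect of the compound at the concentration tested, a lower number a weaker effect), compound 1 gives 33%, in this assay compound 2 gives 55%, and compound 3 gives 90%. Compound 2 thus stands second highest of the three numbers: the step of a number 22 percentage points higher from compound 1 to compound 2 (beyond the scatter) lifts it beyond the scatter above compound 1, and the step of a number 35 percentage points higher from compound 2 to compound 3 (beyond the scatter) sets compound 3 beyond the scatter above it; the step of a number 57 percentage points higher from compound 1 to compound 3 (beyond the scatter) spans the whole measured range.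

Compound 4 differs from compound 2 by a group of 7 heavy atoms (4 carbon, 1 nitrogen, 2 oxygen; one five-membered non-aromatic ring with 1 hetero atom) in place of a group of 10 heavy atoms (7 carbon, 2 nitrogen, 1 sulfur; one six-membered aromatic ring of carbon only), on a double-bonded ring carbon. The three measured steps all vary what sits on the amide-type nitrogen of the group that leaves, with the group itself kept; none replaces that whole group by a 2,5-dioxopyrrolidin-1-yl on the double-bonded ring carbon. Going by the values given here, they show only that the group at this ring carbon moves the read-out strongly in this assay, without fixing a direction for the present change. A step of a number 15 percentage points lower from compound 2 to compound 4 (beyond the scatter) is therefore expected, with wide uncertainty, and compound 4 is estimated at 40%, between 15% and 75%.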

Compound 4, a percentage reported as activity, at one concentration (the size of the read-out at that concentration, not a potency): 70%
Compound 4: the middle estimate sits 30 percentage points below what was measured; measured number inside the range.
By their numbers in this assay, from the lowest: compound 1; then compound 2; then compound 4; then compound 3.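

In this assay the double-bonded ring carbon keeps a substantial read-out when the whole side group with its six-membered aromatic ring gives way to 2,5-dioxopyrrolidin-1-yl, a number 15 percentage points higher from compound 2 to compound 4 (beyond the scatter), so among these compounds neither that aromatic ring nor the hydrogen-bond donors of the leaving group are needed for a number at this level. The new group falls inside the range set by the earlier side groups, a number 37 percentage points higher from compound 1 to compound 4 (beyond the scatter) and a number 20 percentage points lower from compound 3 to compound 4 (beyond the scatter), which leaves the side group carrying the 4-bromophenyl with the highest number of the four, and shows that the read-out at this position does not depend on keeping the earlier type of side group at all. Nothing at hand gives a reason for any of these steps.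

On these data alone, what a plain amino group, a pyrrolidin-1-yl without the two carbonyls or an open-chain acetamide would give on the same ring carbon stays open, and with it whether the carbonyls of the new group matter. Also open, as far as these compounds go, is whether these differences at a single concentration would carry over to potency, and whether a bromo on other side groups would lift the read-out as it does for the phenyl-bearing one.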